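A Piperidin-4-yl Group in Place of Vinyl

The source may hold more compounds than are shown below. What is called first, only, known or untested is meant among the compounds shown, and "the series" means these compounds.

Measured compounds:
compound 1: `c1ccc(-c2nc(-c3c[nH]c4ccccc34)co2)cc1`, 113000 nM
compound 2: `C=Cc1nc(-c2c[nH]c3ccccc23)co1`, 37600 nM

In a functional assay on MIA PaCa-2 cells (Homo sapiens) for cytotoxicity, read by MTT assay, with a stated time of 48 h (a higher number here means a weaker inhibitor, a lower number a stronger inhibitor), compound 1 gives 113000 nM, and compound 2 gives 37600 nM. Of the two numbers, that of compound 2 is the lower; the step of a 3.0-fold lower number from compound 1 to compound 2 (0.48 log units; beyond the scatter) lies beyond the scatter. Compound 3 `c1ccc2c(-c3coc(C4CCNCC4)n3)c[nH]c2c1` has not been measured. It differs from compound 2 by piperidin-4-yl in place of vinyl on an aromatic carbon. Among the measured compounds shown here, only the step from compound 1 to compound 2 bears on this position, and it shows that exchanging the group there moves the number by a modest amount. For the measured compounds named here, no measured pair covers a six-membered non-aromatic ring or a hydrogen-bond donor at this place, so the direction of the change is open. Compound 3 is therefore expected to give a number close to the one just seen, the step of a 1.3-fold lower number from compound 2 to compound 3 (0.10 log units; within the scatter) being expected to stay small. The estimate for compound 3 is 30000 nM, with a range from 8000 nM to 120000 nM.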

Compound 3, half-maximal inhibitory concentration: 230000 nM
Compound 3: the middle estimate sits 7.7-fold (0.88 log units) below what was measured; measured number outside the range, above it.
By their numbers in this assay, from the lowest: compound 2; then compound 1; then compound 3.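

Among the compounds shown here, the position proves sensitive in both directions: exchanging the group there had so far only lowered the number, whereas in this assay piperidin-4-yl raises it, with a 6.1-fold higher number from compound 2 to compound 3 (0.79 log units; beyond the scatter) and a 2.0-fold higher number from compound 1 to compound 3 (0.31 log units; beyond the scatter). Compound 3 is thus the weakest of the three, and neither vinyl nor phenyl gives a number as high as piperidin-4-yl does. Nothing at hand explains why these steps take this direction or size.

The compounds shown leave open whether the higher number goes with the nitrogen of the piperidin-4-yl group or with the six-membered non-aromatic ring as such. A cyclohexyl group at this place would separate those two readings, and an open-chain aminoethyl group would show whether the nitrogen has the same effect without the ring.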